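The compounds below may be only part of what the source reports. "The series", "measured", "known", "first", "only" and "open" are said of these compounds alone.

Compound 3 `CCC(C)(C)Cc1c[nH]c(CCc2ccc(-c3ccc(F)cn3)cc2)n1` gives the lowest number of the three measured compounds in a functional assay on HEK293 cells for agonist activity at Bombesin receptor subtype-3 (Homo sapiens), read by luminescence and calcium flux, with a stated time of 10 min (on this read-out higher numbers stand for an effect only at larger amounts of compound and lower numbers for an effect already at smaller amounts), at 66 nM. Compound 2 `CCC(C)(C)Cc1c[nH]c(CCc2ccc(-c3cccc(C#N)n3)cc2)n1` gives 193 nM in this assay, and compound 1 `CCC(C)(C)Cc1c[nH]c(CCc2ccc(-n3ncnn3)cc2)n1` gives 422 nM. Compound 4 `CCC(C)(C)Cc1c[nH]c(CCc2ccc(-c3csnn3)cc2)n1` carries 1,2,3-thiadiazol-4-yl in place of 5-fluoropyridin-2-yl on an aromatic carbon. The step that bears most on this change is a 6.4-fold lower number from compound 1 to compound 3 (0.81 log units; beyond the scatter), where a five-membered ring with several hetero atoms gave way to a six-membered ring with one; the steps of a 2.2-fold lower number from compound 1 to compound 2 (0.34 log units; beyond the scatter) and a 2.9-fold lower number from compound 2 to compound 3 (0.47 log units; beyond the scatter) also show that the six-membered rings run lower here. Returning to a five-membered ring with three hetero atoms is therefore expected to move the number back up, and compound 4 is estimated at 250 nM, within 90 nM to 700 nM, a step of a 3.8-fold higher number from compound 3 to compound 4 (0.58 log units; beyond the scatter).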

Compound 4, half-maximal effective concentration: 538 nM
Compound 4: the middle estimate sits 2.2-fold (0.33 log units) below what was measured; the range from low to high includes it.
By their numbers in this assay, from the lowest: compound 3; then compound 2; then compounds 1 and 4 (each within the scatter of the next).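

In this assay the 1,2,3-thiadiazol-4-yl group gives an 8.2-fold higher number from compound 3 to compound 4 (0.91 log units; beyond the scatter) and the largest step at this position, and it also gives a 2.8-fold higher number from compound 2 to compound 4 (0.45 log units; beyond the scatter) so that both six-membered rings now stand lower than this five-membered ring. The step of a 1.3-fold higher number from compound 1 to compound 4 (0.11 log units; within the scatter) lies within the scatter and leaves the two five-membered rings level, with no compound shown going against this split by ring size. Nothing measured here explains the split.

Where a plain phenyl or a furan-2-yl ring would fall remains open. Across these compounds ring size and the number of hetero atoms change together, so their contributions cannot be separated.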